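The source may report more compounds than this note shows. Statements on the series, on what has been measured and on what is new or still open speak of the compounds shown alone.

Measured so far in a functional assay on HO8910 cells (Homo sapiens) for inhibition, read by MTT assay, with a stated time of 24 h, tested at 10 ug/mL; a lower number here means less inhibition of growth, a higher number more inhibition of growth at the concentration tested:

compound 1 `CC(=O)SCCC(CCCCC(=O)O)SC(C)=O` gives 1.61%
compound 2 `CC(=O)SCCC(CCCCC(=O)Nc1ccccc1Cl)SC(C)=O` gives "not active" (no number reported)

Compound 2 has no number to stand on. In this assay compound 2 is reported only as "not active" (no number reported), so it cannot be placed at an exact point on the scale. The only figure available is from compound 1, whose 1.61% is small on a scale where higher numbers mean more inhibition of growth.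

The next compound to be tested is compound 3 `CC(=O)SCCC(CCCCC(=O)Nc1ccc(Cl)cc1)SC(C)=O`. It has the same atoms as compound 2, joined differently: 4-chlorophenyl in place of 2-chlorophenyl on an amide-type nitrogen, with 4-chlorophenyl in place of 2-chlorophenyl on an amide-type nitrogen. Going by the values given here, no measured pair shows what a swap of this kind does, so any expectation is only a cautious one. With compound 2 reported as "not active" (no number reported), no step beyond the usual scatter is expected in this assay, and no direction can be named. Compound 3 is estimated at 4%, with an expected range from 0% to 18%, and it may also be reported without a number.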

Compound 3, percent growth inhibition at one concentration: 1.47%
Beside the measured number, compound 3's estimate is 2.5 percentage points above it; the range from low to high includes it.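

Placing the chlorine as in 4-chlorophenyl rather than 2-chlorophenyl on the amide-type nitrogen yields a reading, as in this assay compound 3 gives 1.47% while compound 2 is reported only as "not active", so the step between these two cannot be read. Putting (4-chlorophenyl)amino in place of hydroxy on the carbonyl carbon gives a number 0.1 percentage points lower from compound 1 to compound 3 (within the scatter), which means that the free acid of compound 1 and the amide of compound 3 cannot be told apart here, and both readings sit low on the scale. Nothing available explains these readings.

The compounds shown leave open whether any amide at this carbonyl carbon could raise the inhibition of growth, for example one made with a plain phenyl, a benzyl or a pyridyl group on the nitrogen. They also leave open what free thiol groups in place of the two thioacetyl groups, or a longer chain between the sulfur-bearing carbon and the carbonyl, would do in this assay.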